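The source may report more compounds than this note shows. Statements on the series, on what has been measured and on what is new or still open speak of the compounds shown alone.

Compound 1 `Brc1cn2ccnc2c(-c2ccc3ncn(C4CCCCC4)c3c2)n1`: 21.3%
Compound 2 `O=Cc1ccc(-c2cn3ccnc3c(-c3ccc4ncn(C5CCCCC5)c4c3)n2)cc1`: 21.4%

In a functional assay on SNB-75 cells (Homo sapiens) for inhibition, read by sulforhodamine B assay, with a stated time of 48 h, tested at 10 uM (on this read-out higher numbers stand for more inhibition at the one concentration tested (going by the name of the read-out) and lower numbers for less inhibition), compound 1 gives 21.3% and compound 2 gives 21.4%. Compound 2 thus sits level with compound 1, the step of a number 0.1 percentage points higher from compound 1 to compound 2 (within the scatter) lying within the scatter. Compound 3 `Fc1ccc(-c2cn3ccnc3c(-c3ccc4ncn(C5CCCCC5)c4c3)n2)cc1` carries the change fluoro in place of formyl on an aromatic carbon relative to compound 2. Going by the values given here, the only measured step, exchanging bromo for 4-formylphenyl, gave a number 0.1 percentage points higher from compound 1 to compound 2 (within the scatter), so no measured change has yet moved the read-out beyond the scatter. Compound 3 is therefore expected to show a number 0.4 percentage points lower from compound 2 to compound 3 (within the scatter). Compound 3 is estimated at 21%, ranging from 8% to 34%.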

Compound 3, a percentage reported as inhibition, at one concentration (the size of the read-out at that concentration, not a potency): 21%
Compound 3: the middle estimate sits on the measured number at the digits printed; low and high end bracket the measured number.
By their numbers in this assay, from the lowest: compounds 3, 1 and 2 (each within the scatter of the next).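

Exchanging formyl for fluoro on the aromatic carbon para to a large group gives a number 0.4 percentage points lower from compound 2 to compound 3 (within the scatter) in this assay and so removes the carbonyl's hydrogen-bond acceptor with no change beyond the scatter. Placing 4-fluorophenyl in place of bromo gives a number 0.3 percentage points lower from compound 1 to compound 3 (within the scatter) and shows that a second substituted phenyl group also leaves the read-out level with the bromo compound. No measurement is available that explains this flat result.

Going by these compounds, whether an amine or a carboxylic acid on this carbon would move the read-out beyond the scatter stays open. The same holds for a longer chain in place of the phenyl ring.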